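The source may report more compounds than this note shows. Statements on the series, on what has been measured and on what is new or still open speak of the compounds shown alone.

Compound 1 `CC(C)c1cc(-c2n[nH]c(=O)n2-c2cccc(C(=O)NCCCCCCC(=O)NO)c2)c(O)cc1O` and compound 2 `CC(C)c1cc(-c2n[nH]c(=O)n2-c2ccc(C(=O)NCCCCCCC(=O)NO)cc2)c(O)cc1O` share the same core and the same long chain ending in a hydroxamic acid group; they differ only in where that chain is attached to the outer aromatic ring. In a functional assay on A549 cells (Homo sapiens) for inhibition (on this read-out higher numbers stand for weaker inhibition and lower numbers for stronger inhibition), compound 1 gives 4600 nM, and compound 2 gives 4600 nM. The two values stand level with each other at the digits shown, so compound 1 sits at the same level as its only measured neighbour, and nothing in these two numbers separates them.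

Compound 3 `CC(C)c1cc(-c2n[nH]c(=O)n2-c2cccc(C(=O)NCCCCCC(=O)NO)c2)c(O)cc1O` keeps the attachment point of compound 1 and shortens the chain instead. The change is hydroxycarbamoyl in place of (hydroxycarbamoyl)methyl on a saturated chain carbon, five bonds along the chain from an amide-type nitrogen. For the measured compounds named here, no measured pair shows what such a shortening does here, so the expected direction rests on the level of compound 1 alone. Compound 3 is expected to land close to compound 1, with the step of a 1.0-fold lower number from compound 1 to compound 3 (0.01 log units; within the scatter) expected to stay within the scatter, and its estimated value in this assay is 4500 nM, ranging from 1300 nM to 15000 nM.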

Compound 3, half-maximal inhibitory concentration: 4600 nM
Compound 3: the middle estimate sits 1.0-fold (0.01 log units) below what was measured; the measured number falls inside the stated range.
By their numbers in this assay, from the lowest: compounds 1, 2 and 3 (each within the scatter of the next).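

In this assay, putting hydroxycarbamoyl in place of (hydroxycarbamoyl)methyl on a saturated chain carbon, five bonds along the chain from an amide-type nitrogen, gives no change at the digits printed from compound 1 to compound 3 (within the scatter), so this shortening of the chain leaves the reading where it was. For the compounds shown here, compounds 1 and 2 could speak only to where the chain is attached to the outer aromatic ring, while this step is the first look at the length of the chain itself, and at this attachment point the shorter chain is as good as the longer one on this read-out. Nothing available explains why the reading holds level across this change.

Going by these compounds alone, one step covers only a single change of length at one attachment point, so it remains open whether a longer chain or a much shorter one would hold the same level, and whether the same shortening would read alike on the chain of compound 2. Also open, as far as these compounds go, is what would happen with a carboxylic acid or an amine at the end of the chain in place of hydroxycarbamoyl.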